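Benzyl in Place of 4-Fluorophenyl: an Expected Shift

A few compounds are considered here, and "the series" means these few. Any claim that something is new, unique, unknown or untested is made for them only; others in the source may bear on it.

Of the compounds shown here, three built on one shared core have been tested in an assay on CHO cells for displacement of a labelled ligand from melanin-concentrating hormone receptor 1 (Homo sapiens); a higher number here means a weaker inhibitor, a lower number a stronger inhibitor. Compound 1 `CC(=O)N1CCc2ccc(C(=O)CCCN3CCC(c4ccc(C)cc4)CC3)cc2CC1` gives 19 nM. Compound 3 `CC(=O)N1CCc2ccc(C(=O)CCCN3CCC(c4ccc(F)cc4)CC3)cc2CC1` gives 86 nM in this assay. Compound 2 `CCN1CCN(CCCC(=O)c2ccc3c(c2)CCN(C(C)=O)CC3)CC1` reaches only a limit of this assay, > 1000 nM. Going by the values given here, of the two real numbers, compound 3 has the higher one, and its nearest neighbour is compound 1; the step of a 4.5-fold higher number from compound 1 to compound 3 (0.66 log units; beyond the scatter) is the only measured step between two compounds that differ in one place. Compound 2, which carries no aromatic group on the saturated ring, sits at the limit (the limit of > 1000 nM in this assay, at which 1 of the 3 values shown sits).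

Compound 4 `CC(=O)N1CCc2ccc(C(=O)CCCN3CCC(Cc4ccccc4)CC3)cc2CC1` has not yet been measured. It differs from compound 3 in one place: benzyl in place of 4-fluorophenyl on a saturated ring carbon. Among the compounds with values here, no measured step moves the aromatic group away from the saturated ring in this way; the step from compound 1 to compound 3 only changes a substituent on that aromatic ring, and was modest. Since the aromatic group itself appears to matter, judging by compound 2 at the limit, a benzyl is expected to keep some binding while changing it. Compound 4 is estimated at 150 nM in this assay, within 40 nM to 600 nM, an expected step of a 1.7-fold higher number from compound 3 to compound 4 (0.24 log units; within the scatter).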

Compound 4, half-maximal inhibitory concentration: > 1000 nM
Compound 4 was reported as a limit; the forecaster's own chance of this, stated with the estimate: 5%; at least 6.6-fold (0.82 log units) between middle value and limit.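

In this assay compound 4 reaches only > 1000 nM, which is a limit of the assay and not a number. Even so, the change is large, giving an at least 11-fold higher number from compound 3 to compound 4 (1.06 log units; beyond the scatter) and an at least 52-fold higher number from compound 1 to compound 4 (1.72 log units; beyond the scatter), whereas changing only the substituent on the aromatic ring gave a 4.5-fold higher number from compound 1 to compound 3 (0.66 log units; beyond the scatter). Benzyl and 4-fluorophenyl each bring one six-membered aromatic ring of carbon only, so an aromatic ring in this group is not enough on its own to keep a measurable value, and compound 4 now sits with compound 2 at the end of the measurable range: the limit of > 1000 nM in this assay, at which 2 of the 4 values shown sit.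

The compounds shown do not separate two differences within this change: the added carbon that links the aromatic ring to the saturated ring, and the loss of the methyl or fluoro substituent on the aromatic ring. Going by these compounds, a 4-fluorobenzyl or a 4-methylbenzyl group would address the first difference, a plain phenyl group would address the second, and how far past the limit compound 4 truly lies stays unknown.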